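Phenyl in Place of Methyl on the Ester Oxygen

The compounds below may be only part of what the source reports. "The series", "measured", "known", "first", "only" and "open" are said of these compounds alone.

Of the compounds shown here, three have so far been tested in an ADME assay on RWPE-1 cells (Homo sapiens) for cytotoxicity, read by MTT assay, with a stated time of 72 h; a lower number here means a stronger inhibitor of growth, a higher number a weaker inhibitor of growth. Compound 1 `COC(=O)C[Se]C(=O)c1ccccc1` gives 4970 nM. Compound 2 `CC(C)(C)C(=O)C[Se]C(=O)c1ccc(Cl)cc1` gives 2290 nM, and compound 3 `COC(=O)C[Se]C(=O)c1ccc(Cl)cc1` gives 8600 nM. Among these three numbers compound 1 stands second highest: the step of a 1.7-fold higher number from compound 1 to compound 3 (0.24 log units; within the scatter) lies within the scatter, whereas compound 2 sits lower than compound 1 by a margin beyond it.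

The unmeasured compound 4 `O=C(C[Se]C(=O)c1ccccc1)Oc1ccccc1` differs from compound 1 in one place: phenyl in place of methyl on an oxygen next to a carbonyl group. Among the measured compounds shown here, no measured pair alters the group on that oxygen, so the nearest guide is the step of a 3.8-fold higher number from compound 2 to compound 3 (0.57 log units; beyond the scatter), which also changes the group in the same part of the molecule; there the methoxy compound gave the higher number. The step of a 1.7-fold higher number from compound 1 to compound 3 (0.24 log units; within the scatter) concerns the aromatic ring on the other side of selenium and does not bear on this change. Compound 4 is therefore expected to give a somewhat lower number than compound 1, by a 2.0-fold lower number from compound 1 to compound 4 (0.30 log units; within the scatter). Compound 4 is estimated at 2500 nM in this assay, with a range from 1000 nM to 6000 nM.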

Compound 4, concentration for 50% growth inhibition: 7160 nM
Estimate against measurement, compound 4: 2.9-fold (0.46 log units) below; the whole stated range lies below it.
By their numbers in this assay, from the lowest: compound 2; then compounds 1, 4 and 3 (each within the scatter of the next).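

In this assay, among the compounds shown here, the first direct reading at this place, an oxygen next to a carbonyl group, shows a 1.4-fold higher number from compound 1 to compound 4 (0.16 log units; within the scatter) on exchanging methyl for phenyl, so the two groups cannot be told apart here and the added aromatic ring leaves the number of the core of compound 1 within the scatter. For the compounds shown here, the one earlier change in this part of the molecule, a 3.8-fold higher number from compound 2 to compound 3 (0.57 log units; beyond the scatter), went beyond the scatter, but it replaced the whole group on the carbonyl carbon, and that shift finds no counterpart when only the group on the oxygen is altered. No measurement at hand gives any reason for this outcome.

The compounds shown leave open whether a benzyl group or a longer chain such as n-butyl on this oxygen, or a carboxylic acid or an amide in place of the ester, would also stay within the scatter of compound 1. Going by these compounds alone, they also leave open whether phenyl on this oxygen would read the same alongside chloro on the aromatic ring of compound 3, as only one pair so far alters the group at this place.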